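Ester versus sulfur chains on the shared core

The source may report more compounds than this note shows. Statements on the series, on what has been measured and on what is new or still open speak of the compounds shown alone.

Measured so far:
compound 1 `Nc1c([S+]([O-])CCCF)sc2nc(-c3cccs3)cc(-c3ccccc3)c12` — 6.1 nM
compound 2 `CCOC(=O)c1sc2nc(-c3cccs3)cc(-c3ccccc3)c2c1N` — limit only
compound 3 `CCCC[S+]([O-])c1cc2c(-c3ccccc3)nc(-c3ccccc3)nc2s1` — 93 nM

In an assay for inhibition of 15-hydroxyprostaglandin dehydrogenase [NAD(+)] (Homo sapiens), read by fluorescence, with a stated time of 15 min, in the presence of a further agent that is not named here (on this read-out lower numbers stand for stronger inhibition and higher numbers for weaker inhibition), compound 1 gives 6.1 nM. For compound 2 the result is a limit of the assay only, > 7500 nM, so compound 2 stands at the weak end of the numbers seen (the limit of > 7500 nM in this assay, at which 1 of the 3 values shown sits). Compound 3, on a different core, gives 93 nM in this assay.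

For the measured compounds named here, the one measured step that bears on the change at hand is an at least 1200-fold higher number from compound 1 to compound 2 (3.08 log units; beyond the scatter), which moved from a sulfur-bearing chain to the ester and ran to the limit. Compound 4 `CCCCSc1sc2nc(-c3cccs3)cc(-c3ccccc3)c2c1N`, not yet measured, turns that exchange partly back: butylsulfanyl in place of ethoxycarbonyl on an aromatic carbon. The group that enters is a sulfur chain of the same kind as in compound 1 and compound 3, though without the oxygen on the sulfur that both carry.

Since the sulfur-to-ester step was large and lost all measurable inhibition, a return to a sulfur chain is expected to recover a large part of it, so from compound 2 to compound 4 a large fall in number is expected, an at least 180-fold lower number from compound 2 to compound 4 (2.27 log units; beyond the scatter). From the compounds shown here alone, whether the sulfide matches the sulfoxide of compound 1 is unknown from these three compounds, so the expected value for compound 4 is set between compound 1 and compound 3: 40 nM, within 6 nM to 400 nM.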

Compound 4, half-maximal inhibitory concentration: > 80 nM
Compound 4 was reported as a limit; the forecaster's own chance of this, stated with the estimate: 10%; at least 2.0-fold (0.30 log units) between middle value and limit.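

In this assay compound 4 gives > 80 nM, a limit of the assay and not a number. On this aromatic carbon next to the ring sulfur, a sulfur chain is therefore not enough by itself to match the sulfur-bearing chain of compound 1, which carries an oxygen on the sulfur and a fluorine at its end; the measured comparison is an at least 13-fold higher number from compound 1 to compound 4 (1.11 log units; beyond the scatter). From the compounds shown here alone, both values in the exchange of ethoxycarbonyl for butylsulfanyl are limits, so that step cannot be read, and the order of compound 2 and compound 4 stays unknown.

The step to compound 4 changes the oxygen on the sulfur, the chain length and the fluorine together, so the compounds shown do not separate these changes; a 3-fluoropropylsulfanyl or a butylsulfinyl group on the shared core would each alter only part of that difference. Going by these compounds, it also remains open how a butylsulfonyl group at this position would compare with the chain of compound 1, and how far the number of compound 4 lies beyond its limit.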